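The compounds below may be only part of what the source reports. "The series", "measured", "known", "first", "only" and "open" are said of these compounds alone.

Among the compounds with values here, compound 1, with the structure `COc1cc(OC)c(/C=C/S(=O)(=O)Cc2ccc(C#N)cc2)c(OC)c1`, is one of three compounds measured in a functional assay on DLD-1 cells (Homo sapiens) for antiproliferative activity, read by trypan blue exclusion; a higher number here means a weaker inhibitor, a lower number a stronger inhibitor. In this assay compound 1 gives 20000 nM, the highest number among the three. Compound 3, `COc1ccc(CS(=O)(=O)/C=C/c2ccc(C)cc2C)cc1`, gives 15000 nM, a number that lies within the scatter of compound 1, so the two cannot be told apart. Compound 2, `COc1ccc(CS(=O)(=O)/C=C/c2ccccc2OC)cc1`, gives 7500 nM, a number that stands beyond the scatter below compound 1. Compound 4, `COc1ccc(CS(=O)(=O)/C=C/c2c(OC)cc(OC)cc2OC)cc1`, has not yet been measured. It differs from compound 1 in one place: methoxy in place of cyano on an aromatic carbon. Within the data shown here, no pair of measured compounds differing in exactly one place is available, so the size of this step cannot be read from the data. Compounds 2 and 3 both carry the methoxy on the benzylic ring and give the lower numbers, which suggests a modest gain. The step from compound 1 to compound 4 is therefore expected to be a 2.0-fold lower number from compound 1 to compound 4 (0.30 log units; within the scatter). Compound 4 is estimated to give 10000 nM, with a likely range from 3000 nM to 30000 nM.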

Compound 4, half-maximal inhibitory concentration: 40 nM
Beside the measured number, compound 4's estimate is 250-fold (2.40 log units) above it; the measured number lies below the stated range.
By their numbers in this assay, from the lowest: compound 4; then compounds 2, 3 and 1 (each within the scatter of the next, the first and the last beyond it).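

In this assay, within the data shown here, the exchange of cyano for methoxy on an aromatic carbon, para to a large group, turning 4-cyanophenyl into 4-methoxyphenyl, comes with a 500-fold lower number from compound 1 to compound 4 (2.70 log units; beyond the scatter) and gives the first single-place step. It shows that this one position can carry a very large change in antiproliferative potency, even though the two groups match in heavy-atom count and hydrogen-bond acceptor count, and neither bears a net charge. Nothing at hand accounts for the size of this step.

With only cyano and methoxy at this position, the compounds shown do not tell how a hydroxyl, an ethoxy, a chlorine or an amine there would compare. From the compounds shown here alone, whether a step of this size would recur on a different core also remains open.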